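This account rests on a few compounds, and the source may have more. Where it says the series, first, only, none or still open, it means among the compounds named here.

Measured compounds:
- compound 1 `COc1ccc(Cn2c(-c3ccc(C)cc3)c(Br)c(=O)c3cc([N+](=O)[O-])ccc32)cc1`: 4220 nM
- compound 2 `Cc1ccc(-c2c(Br)c(=O)c3cc([N+](=O)[O-])ccc3n2C(C)c2ccccc2)cc1`: 1340 nM

Both compounds were tested in an assay on isolated protein for inhibition of alkaline phosphatase, tissue-nonspecific isozyme (Bos taurus), read by spectrophotometry, with stated times of 7 min and 15 min; on this read-out lower numbers stand for stronger inhibition and higher numbers for weaker inhibition. Of the two numbers, compound 1 has the higher one, so it is the weaker inhibitor of the pair; the step of a 3.1-fold lower number from compound 1 to compound 2 (0.50 log units; beyond the scatter) separates it from compound 2, which exchanges the group on the aromatic nitrogen while leaving the rest of the shared core untouched.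

Compound 3 `CCc1ccc(-c2c(-c3ccc(C)cc3)n(Cc3ccc(OC)cc3)c3ccc([N+](=O)[O-])cc3c2=O)cc1` has not yet been measured. It differs from compound 1 in one place: 4-ethylphenyl in place of bromo on an aromatic carbon. For the measured compounds named here, this change concerns a different position of the core than the one measured step does, so the step from compound 1 to compound 2 gives no direct guidance on how a 4-ethylphenyl group at the site of the bromo will behave. Going by the values given here, no measured pair shows an exchange of this kind. With only that to go on, compound 3 is expected to land near compound 1, and the estimated step of a 1.2-fold lower number from compound 1 to compound 3 (0.08 log units; within the scatter) is small, with direction uncertain. The estimate for compound 3 in this assay is 3500 nM, with a range from 800 nM to 15000 nM.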

Compound 3, half-maximal inhibitory concentration: 1660 nM
Estimate against measurement, compound 3: 2.1-fold (0.32 log units) above; measured number inside the range.
By their numbers in this assay, from the lowest: compounds 2 and 3 (each within the scatter of the next); then compound 1.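

In this assay, the site that holds the bromo in compound 1 tolerates a much bigger group: 4-ethylphenyl, with 8 heavy atoms and a six-membered aromatic ring, replaces a single bromine and gives a 2.5-fold lower number from compound 1 to compound 3 (0.41 log units; beyond the scatter). For the compounds shown here, the earlier pair changed only the group on the aromatic nitrogen, so this is the first sign that the carbon ortho to the 4-methylphenyl group can also shift the number, and that the shift at this site can be towards stronger inhibition. Going by these compounds alone, nothing measured here explains this gain, and the one step cannot separate the loss of bromine from the arrival of the new ring or its ethyl group.

The compounds shown leave open whether a plain phenyl ring, an ethyl chain alone, an amine or a carboxylic acid at this site would give a similar number. They also leave open whether 4-ethylphenyl at this site and 1-phenylethyl on the aromatic nitrogen would work together when both sit on the shared core.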